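This account rests on a few compounds, and the source may have more. Where it says the series, first, only, none or still open, it means among the compounds named here.

Measured so far:
compound 1 `c1ccc(Cn2ccc3nc(-c4ccccc4)nc-3c2)cc1` gives > 100000 nM (limit)
compound 2 `Cc1ccc(Cn2ccc3nc(-c4ccccc4)nc-3c2)cc1` gives > 100000 nM (limit)
compound 3 `Clc1ccc(Cn2ccc3nc(-c4ccccc4)nc-3c2)cc1` gives > 100000 nM (limit)

In an ADME assay on MDBK cells (Bos taurus) for cytotoxicity (a lower number here means that less compound is tolerated, a higher number that more compound is tolerated), compound 1 stands at > 100000 nM as a limit of the assay and not a number. The other two readings are no different in kind, with the limit of > 100000 nM in this assay, at which 3 of the 3 values shown sit, as the whole picture so far. Compound 4 `FC(F)(F)c1ccccc1Cn1ccc2nc(-c3ccccc3)nc-2c1` differs from compound 1 by trifluoromethyl in place of hydrogen on an aromatic carbon as trifluoromethyl in place of hydrogen on an aromatic carbon, ortho to a large group. The nearest measured changes are a step that the two limits leave unreadable from compound 1 to compound 2 and a step that the two limits leave unreadable from compound 1 to compound 3 and a step that the two limits leave unreadable from compound 2 to compound 3 and none gives a size to carry over. No shift beyond the scatter is expected in this assay in either direction. The expectation is a number no higher from compound 1 to compound 4 (the limit leaves the size open) for this change. For compound 4 the estimated value is 100000 nM with an expected range from 40000 nM to 200000 nM and a report as a limit is the likeliest outcome.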

Compound 4, half-maximal cytotoxic concentration: > 100000 nM
Compound 4: a limit, no number (the forecaster's own chance of this, stated with the estimate: 80%); the middle value lies on the limit itself.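

Compound 1 and compound 4 both read as limits of the assay and not numbers, so no new step can be read: the limit of > 100000 nM in this assay, at which 4 of the 4 values shown sit.

The compounds shown leave open whether methyl, chloro or trifluoromethyl shifts the reading in this assay at all.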